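A few compounds are considered here, and "the series" means these few. Any claim that something is new, unique, unknown or untested is made for them only; others in the source may bear on it.

Measured in a functional assay on HeLa cells (Homo sapiens) for cytotoxicity, read by MTT assay, with a stated time of 48 h; a lower number here means a stronger inhibitor, a higher number a weaker inhibitor:
- compound 1 `Cc1ccc(Cn2cc(COc3ccc4c(=O)ccoc4c3)nn2)cc1`: > 100000 nM, a limit
- compound 2 `O=c1ccoc2cc(OCc3cn(Cc4cccc([N+](=O)[O-])c4)nn3)ccc12`: 17300 nM

Among the measured compounds shown here, compound 2 holds the only true number so far, 17300 nM. Compound 3 `O=c1ccoc2cc(OCc3cn(Cc4ccccc4Br)nn3)ccc12` has 2-bromophenyl in place of 3-nitrophenyl on a saturated chain carbon bound to an aromatic nitrogen. For the measured compounds named here, one measured step bears on this place: an at least 5.7-fold lower number from compound 1 to compound 2 (0.76 log units; beyond the scatter), and its size is bounded by the limit of > 100000 nM in this assay, at which 1 of the 2 values shown sits. Compound 3 also gives up the 3-nitrophenyl, so part of that step is expected to reverse in this assay, with a modest rise: a 1.7-fold higher number from compound 2 to compound 3 (0.24 log units; within the scatter). For compound 3 the estimate is 30000 nM, with an expected range of 10000 nM to 100000 nM.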

Compound 3, half-maximal inhibitory concentration: 14500 nM
Estimate against measurement, compound 3: 2.1-fold (0.32 log units) above; low and high end bracket the measured number.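

Exchange at this place gives a 1.2-fold lower number from compound 2 to compound 3 (0.08 log units; within the scatter), so in this assay the hydrogen-bond acceptors that leave with 3-nitrophenyl bring no shift beyond the scatter. Replacing 4-methylphenyl with 2-bromophenyl gives an at least 6.8-fold lower number from compound 1 to compound 3 (0.83 log units; beyond the scatter), so the drop seen with 3-nitrophenyl is not tied to that one group. The value of compound 1 is a limit and not a number, so the size of this step is only bounded: the limit of > 100000 nM in this assay, at which 1 of the 3 values shown sits.

Open, on these data alone, is how an amine or a carboxylic acid on the phenyl ring, or a longer chain at the saturated chain carbon, would read in this assay. Also open, as far as these compounds go, is whether any group at this place gives a number clearly lower than those of compound 2 and compound 3.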